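This account rests on a few compounds, and the source may have more. Where it says the series, first, only, none or still open, it means among the compounds named here.

Measured so far:
Compound 1 `COC(=O)c1ccc(NCc2cncn2Cc2ccccc2)cc1-c1ccccc1`: in a toxicity assay on NIH3T3 cells (Mus musculus) for cytotoxicity, read by resazurin assay (on this read-out lower numbers stand for an effect already at smaller amounts and higher numbers for an effect only at larger amounts of compound), compound 1 gives > 1000 nM, a limit of the assay.
Compound 2 `COC(=O)c1ccc(NCc2cncn2Cc2ccccc2N)cc1-c1ccccc1`: in this assay compound 2 gives 25000 nM.
Compound 3 `c1ccc(-c2ccc(Cn3cncc3CNc3ccc(-c4cncs4)c(-c4ccccc4)c3)cc2)cc1`: in this assay compound 3 gives > 1000 nM, a limit of the assay.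

The change from compound 1 to compound 2 is amino in place of hydrogen on an aromatic carbon. Its step that the limit leaves unreadable from compound 1 to compound 2 has no readable size because of the limit of > 1000 nM in this assay, at which 2 of the 3 values shown sit. Compound 3 likewise sits at the limit of > 1000 nM in this assay, at which 2 of the 3 values shown sit. The difference between the cores of compound 1 and compound 3 is not broken down here. Compound 4 `Nc1cc(-c2ccccc2)ccc1Cn1cncc1CNc1ccc(-c2cncs2)c(-c2ccccc2)c1`, not yet measured, differs from compound 3 by amino in place of hydrogen on an aromatic carbon; this is the same kind of change as that from compound 1 to compound 2, though here the place is also meta to a phenyl group. The expected step is a step that the limit leaves unreadable from compound 3 to compound 4, resting on compound 2 giving a readable value 25000 nM after the same change. The estimate for compound 4 in this assay is 20000 nM, expected between 3000 nM and 80000 nM.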

Compound 4, half-maximal effective concentration: > 1000 nM
Compound 4 was reported as a limit; the forecaster's own chance of this, stated with the estimate: 40%; the middle value does not contradict the limit.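

No step can be read from compound 3 to compound 4, because both values are limits: the limit of > 1000 nM in this assay, at which 3 of the 4 values shown sit.

The compounds shown leave open how far amino in place of hydrogen on an aromatic carbon shifts the value in this assay, on either core.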